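This account rests on a few compounds, and the source may have more. Where it says the series, first, only, none or still open, it means among the compounds named here.

Compound 1 `CC(C)N(c1cccc(N2CCN(C)CC2)c1)S(=O)(=O)c1ccc2ccccc2c1` carries an isopropyl group on its sulfonamide nitrogen and a naphthalen-2-yl group on the sulfonyl sulfur. In an in vitro assay on CHOKI cells for displacement of a labelled ligand from D(4) dopamine receptor (Homo sapiens) (a higher number here means a weaker inhibitor, a lower number a stronger inhibitor), compound 1 gives > 1000 nM, which is a limit of the assay and not a number. Among the compounds with values here, its one measured neighbour is compound 2 `CC(C)N(c1cccc(N2CCN(C)CC2)c1)S(=O)(=O)c1cccc2ccccc12`, in which naphthalen-1-yl stands in place of naphthalen-2-yl on the sulfonyl sulfur. In this assay compound 2 gives > 10000 nM, again a limit rather than a number. The step that the two limits leave unreadable from compound 1 to compound 2 cannot be read because the limit of > 1000 nM in this assay, at which 1 of the 2 values shown sits, and the limit of > 10000 nM in this assay, at which 1 of the 2 values shown sits, both cap the values. Compound 3 `CN1CCN(c2cccc(N(C)S(=O)(=O)c3ccc4ccccc4c3)c2)CC1` differs from compound 1 in one place: methyl in place of isopropyl on a sulfonamide nitrogen. Within the data shown here, no measured step bears on this change; the only measured step concerns the sulfonyl substituent, not the sulfonamide nitrogen, and it is itself unreadable. The expectation therefore rests on where compound 1 stands, which is at a limit of weak inhibition. Compound 3 is expected to remain in the weak range, with an estimated step that the limit leaves unreadable from compound 1 to compound 3 and an estimated value of 3000 nM (range 800 nM to 20000 nM).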

Compound 3, half-maximal inhibitory concentration: > 10000 nM
Compound 3: only a limit was reported; the forecaster's own chance of this, stated with the estimate: 60%; middle value at least 3.3-fold (0.52 log units) from the limit.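

In this assay compound 3 gives > 10000 nM, a limit of the assay and not a number. Compound 1 also stands at a limit, so the step between compound 1 and compound 3 cannot be read. The compounds shown leave open how strongly each one actually inhibits, and whether either single change moves the value at all.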